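A methyl to methoxy change at compound 2

A few compounds are considered here, and "the series" means these few. Any claim that something is new, unique, unknown or untested is made for them only; others in the source may bear on it.

- Compound 1 `O=C(Nc1ccc(O)c2c(=O)cc(-c3ccccc3Cl)oc12)c1ccc(Cl)cc1`: 4600 nM
- Compound 2 `Cc1ccc(C(=O)Nc2ccc(O)c3c(=O)cc(-c4ccccc4Cl)oc23)cc1`: 10000 nM

In a functional assay on MCF7 cells (Homo sapiens) for antiproliferative activity (on this read-out lower numbers stand for stronger inhibition and higher numbers for weaker inhibition), compound 2 stands highest of the two measured compounds, at 10000 nM. Compound 3 `COc1ccc(C(=O)Nc2ccc(O)c3c(=O)cc(-c4ccccc4Cl)oc23)cc1` carries methoxy in place of methyl on an aromatic carbon, para to a large group (methoxy in place of methyl on an aromatic carbon). Among the compounds with values here, one measured step bears on this, the modest 2.2-fold higher number from compound 1 to compound 2 (0.34 log units; beyond the scatter), which replaced chloro with methyl on an aromatic carbon. It sets a rough size but gives no direction for methoxy, so only a small change is expected, with the estimated step being a 1.3-fold lower number from compound 2 to compound 3 (0.10 log units; within the scatter). The estimate for compound 3 is 8000 nM, with an expected range from 3000 nM to 20000 nM.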

Compound 3, half-maximal inhibitory concentration: 3500 nM
The estimate for compound 3 lay 2.3-fold (0.36 log units) above the measured number; low and high end bracket the measured number.
By their numbers in this assay, from the lowest: compounds 3 and 1 (each within the scatter of the next); then compound 2.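

In this assay, the change from 4-methylphenyl to 4-methoxyphenyl moves the read-out beyond the scatter (a 2.9-fold lower number from compound 2 to compound 3 (0.46 log units; beyond the scatter)). Methoxy and chloro at this position do not separate (a 1.3-fold lower number from compound 1 to compound 3 (0.12 log units; within the scatter)), so among the three groups shown, methyl alone stands apart, on the weaker side. No measurement shown here accounts for this result.

The compounds shown leave open whether the oxygen of methoxy matters in itself, which a hydroxyl or an amine at this position could test. They also leave open whether a longer chain, such as ethoxy, would go beyond the level shared by compound 1 and compound 3.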